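The source may hold more compounds than are shown below. What is called first, only, known or untested is meant among the compounds shown, and "the series" means these compounds.

Among the measured compounds shown here, compound 2, `Cc1ccc(OCC(=O)N(CCCO)Cc2cccs2)cc1`, is one of three compounds measured in an assay on HEK293 cells for agonist activity at transient receptor potential cation channel subfamily M member 8 (Homo sapiens), read by fluorescence and calcium flux, with a stated time of 15 min; a higher number here means that more compound is needed for the effect, a lower number that less compound is needed. In this assay compound 2 gives 3000 nM, the highest of the three numbers. Compound 3, `CCN(Cc1cccs1)C(=O)COc1ccccc1`, gives 1400 nM in this assay, and its gap to compound 2 lies beyond the usual scatter. Compound 1, `CCN(Cc1cccs1)C(=O)C(C)Oc1ccc(C)cc1`, gives 889 nM in this assay, the value furthest from compound 2 and likewise beyond the scatter. For the measured compounds named here, no single-point step between any two of these measured compounds is available, so only the values themselves can be set side by side.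

Compound 4, `CON(Cc1cccs1)C(=O)COc1ccc(C)cc1`, has not yet been measured in this assay. It differs from compound 2 in one place: methoxy in place of 3-hydroxypropyl on an amide-type nitrogen. Because compound 3 gives 1400 nM and compound 1 gives 889 nM, both carrying a group other than 3-hydroxypropyl on the amide-type nitrogen, the number for compound 4 is expected to move downward rather than upward. The expected step from compound 2 to compound 4 in this assay is a 2.0-fold lower number from compound 2 to compound 4 (0.30 log units; within the scatter), a modest decrease that may or may not clear the scatter. Compound 4 is therefore estimated to give 1500 nM in this assay, within a range from 600 nM to 4000 nM.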

Compound 4, half-maximal effective concentration: 10 nM
The estimate for compound 4 lay 150-fold (2.18 log units) above the measured number; the measured number lies below the stated range.
By their numbers in this assay, from the lowest: compound 4; then compounds 1 and 3 (each within the scatter of the next); then compound 2.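

In this assay, among the compounds shown here, the exchange of 3-hydroxypropyl for methoxy on the amide-type nitrogen gives a 300-fold lower number from compound 2 to compound 4 (2.48 log units; beyond the scatter) and is the first single-place comparison in this set. Compounds 1 and 3 each differ from compound 2 in more than one place and could only be set beside it by value. It shows that this position on the amide-type nitrogen can carry a large change in the number on its own, with the rest of the structure held constant. Nothing at hand gives a measured reason for the size of this step.

For the compounds shown here, the single step replaces a longer chain bearing a hydrogen-bond donor with a shorter group bearing none, so it cannot tell which of these differences goes with the lower number. The compounds shown also leave open whether an ethoxy group, a methyl group or a longer chain ending in an amine on the same nitrogen would give a number as low as that of compound 4.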